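Notes on benzyl group changes at one chain carbon

A few compounds are considered here, and "the series" means these few. Any claim that something is new, unique, unknown or untested is made for them only; others in the source may bear on it.

Values in a functional assay on HOS cells (Homo sapiens) for antiproliferative activity, with a stated time of 72 h; a lower number here means a stronger inhibitor, a higher number a weaker inhibitor
- compound 1 `OC[C@H]1O[C@@H](n2cnc3c(NCc4ccc(F)cc4)ncnc32)[C@H](O)[C@@H]1O` gives 13200 nM
- compound 2 `Cc1cccc(CNc2ncnc3c2ncn3[C@@H]2O[C@H](CO)[C@@H](O)[C@H]2O)c1` gives > 166000 nM (a limit)

Compound 2 stands at > 166000 nM in this assay, which is a limit and not a number.

Compound 3 `COc1ccc(CNc2ncnc3c2ncn3[C@@H]2O[C@H](CO)[C@@H](O)[C@H]2O)c(OC)c1` differs from compound 2 by one change: 2,4-dimethoxyphenyl in place of 3-methylphenyl on a saturated chain carbon bound to a nitrogen on an aromatic ring. Going by the values given here, one measured step bears on this place: an at least 12-fold higher number from compound 1 to compound 2 (1.09 log units; beyond the scatter), a large step beyond the scatter. Among the compounds with values here, with only this step as a guide, and no measured compound carrying 2,4-dimethoxyphenyl, the direction is uncertain, and a modest move to a lower number is expected. The expected step is an at least 1.8-fold lower number from compound 2 to compound 3 (0.26 log units; that floor lies within the scatter). For compound 3 the estimated value is 90000 nM, with an expected range of 25000 nM to 300000 nM.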

Compound 3, half-maximal inhibitory concentration: > 166000 nM
Compound 3 ended at the assay's limit (the forecaster's own chance of this, stated with the estimate: 50%); middle value at least 1.8-fold (0.26 log units) away from the limit.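

In this assay compound 3 gives > 166000 nM, a limit and not a number. Replacing 4-fluorophenyl with 2,4-dimethoxyphenyl gives an at least 12-fold higher number from compound 1 to compound 3 (1.09 log units; beyond the scatter), so a second group at this place, one carrying two hydrogen-bond acceptors, also falls far behind compound 1. The step between compound 2 and compound 3 cannot be read, and the series now bunches at one ceiling: the limit of > 166000 nM in this assay, at which 2 of the 3 values shown sit.

On these data alone, whether 4-chlorophenyl or unsubstituted phenyl at this place keeps a readable value stays open. As far as these compounds go, how far compound 2 and compound 3 lie past the limit also stays open.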